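From Pyrimidine Back to a Pyridine Ring

The compounds below may be only part of what the source reports. "The series", "measured", "known", "first", "only" and "open" are said of these compounds alone.

Measured in an assay on HEK293 cells for inhibition of kynurenine 3-monooxygenase (Homo sapiens), read by LC-MS, with a stated time of 20 h (on this read-out higher numbers stand for weaker inhibition and lower numbers for stronger inhibition), so far:
Compound 1, `C[C@@H](Oc1cc2oc(=O)n(CCC(=O)O)c2cc1Cl)c1ccc(Cl)cn1`, gives 100 nM.
Compound 2, `C[C@@H](Oc1cc2oc(=O)n(CCC(=O)O)c2cc1Cl)c1ncccn1`, gives 3160 nM.

Among the measured compounds shown here, compound 2 stands highest of these two numbers; its only neighbour is compound 1, and the two are separated by a 32-fold higher number from compound 1 to compound 2 (1.50 log units; beyond the scatter). Compound 3, `Cc1cccc([C@@H](C)Oc2cc3oc(=O)n(CCC(=O)O)c3cc2Cl)n1`, differs from compound 2 in one place: 6-methylpyridin-2-yl in place of pyrimidin-2-yl on a saturated chain carbon bound to an oxygen on an aromatic ring and a saturated chain carbon. For the measured compounds named here, the single measured step that touches this position is a 32-fold higher number from compound 1 to compound 2 (1.50 log units; beyond the scatter), in which 5-chloropyridin-2-yl gave way to pyrimidin-2-yl and the number rose. Compound 3 reverses that exchange in kind, restoring a pyridine ring, though now one carrying a methyl group rather than a chlorine, so a fall in this assay is expected, toward compound 1 but not necessarily all the way back. The expected step is a 13-fold lower number from compound 2 to compound 3 (1.10 log units; beyond the scatter). Compound 3 is therefore estimated at 250 nM, with a range from 60 nM to 1000 nM.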

Compound 3, half-maximal inhibitory concentration: 316 nM
For compound 3 the middle estimate is 1.3-fold (0.10 log units) below the measured one; low and high end bracket the measured number.
By their numbers in this assay, from the lowest: compound 1; then compound 3; then compound 2.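

Returning to a pyridine pays off even without the chlorine: the exchange gives a 10-fold lower number from compound 2 to compound 3 (1.00 log units; beyond the scatter) and so the gain does not depend on 5-chloropyridin-2-yl alone. The two pyridines are not interchangeable, however, as replacing the chlorinated ring with 6-methylpyridin-2-yl gives a 3.2-fold higher number from compound 1 to compound 3 (0.50 log units; beyond the scatter) and leaves part of the potency unrecovered. Among these compounds, both pyridine-bearing compounds give lower numbers than pyrimidin-2-yl, and none goes against that order.

A plain pyridin-2-yl, carrying neither methyl nor chlorine, or a 5-methylpyridin-2-yl would help separate the contribution of the ring from that of the group on it and of where that group sits. No measurement at hand offers an explanation for these differences.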